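The source may report more compounds than this note shows. Statements on the series, on what has been measured and on what is new or still open speak of the compounds shown alone.

Measured so far in a physicochemical assay for lipophilicity, read by HPLC, in phosphate buffer, measured as chromatographic lipophilicity, at pH 7.4; on this read-out lower numbers stand for lower lipophilicity and higher numbers for higher lipophilicity:
compound 1, `COc1ccc2nc(C)cc(OCC(=O)NCc3cc(C)cc(C)c3)c2c1` — 5.25
compound 2, `COc1ccc2nc(C)cc(NCC(=O)Nc3cc(C)cc(C)c3)c2c1` — 3.59

Compound 1 stands highest of the two numbers in this assay. Compound 2 sits well below it, and the gap between the two is beyond the usual scatter of the measurement. For the measured compounds named here, no two measured compounds differ in a single place, so no directly comparable step exists within the data; what compound 1 and compound 2 show is only that two different arrangements of the shared core and its side chain give clearly different readings.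

Compound 3, `COc1ccc2nc(C)cc(OCC(=O)Nc3ccncn3)c2c1`, has not yet been measured in this assay. Relative to compound 1 the change is as follows: pyrimidin-4-yl in place of 3,5-dimethylbenzyl on an amide-type nitrogen.

Expectation: a large downward step in this assay, clearly beyond the scatter, is expected, since only the amide substituent changes and compound 1 gives 5.25 as the starting point. The estimated move is a number 2.05 log units lower from compound 1 to compound 3 (beyond the scatter). For compound 3 the estimate in this assay is 3.2, with a range from 2.5 to 3.9.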

Compound 3, distribution coefficient: 2.53
Compound 3: the middle estimate sits 0.67 log units above what was measured, within the range that was stated.
By their numbers in this assay, from the lowest: compound 3; then compound 2; then compound 1.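

The amide-type nitrogen is now the one place where a single change can be read: with pyrimidin-4-yl in place of 3,5-dimethylbenzyl, the reading in this assay is a number 2.72 log units lower from compound 1 to compound 3 (beyond the scatter). This one change bundles several differences, since 3,5-dimethylbenzyl has 9 heavy atoms, all carbon, and 0 hydrogen-bond acceptors, while pyrimidin-4-yl has 6 heavy atoms, 2 of them nitrogen, and 2 hydrogen-bond acceptors. Nothing measured independently bears on which of these differences accounts for the size of the step.

Open, from the compounds shown here alone, is how the step divides among the ring nitrogens, the two methyl groups and the attachment of the ring, which plain benzyl, phenyl and pyridin-4-yl on the same amide-type nitrogen would help to separate. Also open, going by these compounds, is whether a step of this size would recur with a longer chain between the amide-type nitrogen and the ring, or with an amine in place of the ether oxygen while the rest of compound 3 stays the same.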